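This account rests on a few compounds, and the source may have more. Where it says the series, first, only, none or still open, it means among the compounds named here.

In a functional assay on PC-3 cells (Homo sapiens) for cytotoxicity, read by MTT assay, with a stated time of 72 h (a higher number here means a weaker inhibitor, a lower number a stronger inhibitor), compound 3 `Cc1ccc2nc(NC(=O)c3cn(-c4ccccc4)nc3-c3ccc(F)cc3)sc2c1` gives 20500 nM. Compound 1 `O=C(Nc1nc2ccccc2s1)c1cn(-c2ccccc2)nc1-c1ccc(F)cc1` gives 7130 nM, and the step of a 2.9-fold higher number from compound 1 to compound 3 (0.46 log units; beyond the scatter) is modest but real. Compound 2 `COc1ccc2nc(NC(=O)c3cn(-c4ccccc4)nc3-c3ccc(F)cc3)sc2c1` gives 12800 nM; the steps of a 1.8-fold higher number from compound 1 to compound 2 (0.25 log units; within the scatter) and a 1.6-fold higher number from compound 2 to compound 3 (0.20 log units; within the scatter) both sit within the scatter, so compound 3 and compound 2 cannot be told apart. Compound 4 `COc1ccc(-c2nn(-c3ccccc3)cc2C(=O)Nc2nc3ccc(C)cc3s2)cc1` differs from compound 3 by methoxy in place of fluoro on an aromatic carbon. Going by the values given here, none of the measured steps touches this ring: all three swap groups on the shared core. Among the compounds with values here, with no step to lean on, compound 4 is expected to land near compound 3, with a change of about a 1.0-fold lower number from compound 3 to compound 4 (0.01 log units; within the scatter) and a wide margin. Compound 4 is therefore estimated at 20000 nM in this assay, between 7000 nM and 55000 nM.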

Compound 4, half-maximal inhibitory concentration: 15900 nM
Compound 4: middle estimate off by 1.3-fold (0.10 log units), on the high side, within the range that was stated.
By their numbers in this assay, from the lowest: compounds 1, 2, 4 and 3 (each within the scatter of the next, the first and the last beyond it).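

In this assay, methoxy in place of fluoro gives a 1.3-fold lower number from compound 3 to compound 4 (0.11 log units; within the scatter) and so stays within the scatter. Going by these compounds alone, the earlier steps all swapped groups on the shared core, so this is the first reading at this position: on this evidence, going from 4-fluorophenyl to 4-methoxyphenyl leaves the number effectively unchanged. No measurement here offers a reason for this result.

An amine or a carboxylic acid at this position could still move the number beyond the scatter. On these data alone, whether the same swap behaves alike on the cores of compound 1 and compound 2 also stays open.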